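The compounds below may be only part of what the source reports. "The series", "measured", "known", "first", "only" and "open" are said of these compounds alone.

Among the compounds with values here, compound 2 `Cc1nn(-c2nc(-c3ccc(Cl)c(Cl)c3)c(SC(C)C)s2)c(C(=O)O)c1-c1ccccc1[N+](=O)[O-]` gives 4700 nM in a functional assay on BJAB cells (Homo sapiens) for antiproliferative activity, with a stated time of 4 days (a lower number here means that less compound is needed, a higher number that more compound is needed for the effect), the higher of the two numbers measured so far. Within the data shown here, compound 1 `Cc1nn(-c2nc(-c3ccc(Cl)c(Cl)c3)c(SC(C)C)s2)c(C(=O)O)c1-c1cccc(F)c1` gives 900 nM in this assay, and the only measured step at this position is a 5.2-fold higher number from compound 1 to compound 2 (0.72 log units; beyond the scatter). Compound 3 `Cc1cccc(-c2c(C)nn(-c3nc(-c4ccc(Cl)c(Cl)c4)c(SC(C)C)s3)c2C(=O)O)c1` differs from compound 2 by 3-methylphenyl in place of 2-nitrophenyl on an aromatic carbon. Among the measured compounds shown here, that single step, which swapped 2-nitrophenyl for 3-fluorophenyl, is the sole guide, and a downward step of comparable size is expected for compound 3, a 4.7-fold lower number from compound 2 to compound 3 (0.67 log units; beyond the scatter). Compound 3 is therefore estimated to give 1000 nM in this assay, with a range from 400 nM to 3000 nM.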

Compound 3, half-maximal effective concentration: 17000 nM
For compound 3 the middle estimate is 17-fold (1.23 log units) below the measured one; measured number above the stated range.
By their numbers in this assay, from the lowest: compound 1; then compound 2; then compound 3.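

In this assay the change to 3-methylphenyl gives a 3.6-fold higher number from compound 2 to compound 3 (0.56 log units; beyond the scatter) and so takes the highest number of the series away from the 2-nitrophenyl compound. Methyl in place of fluoro on an aromatic carbon gives a 19-fold higher number from compound 1 to compound 3 (1.28 log units; beyond the scatter) and shows that exchanging this one substituent on the phenyl group moves the number further than the earlier step did. Nothing at hand accounts for this change. The compounds shown leave open how an amine or a methoxy group on this phenyl group would read, and how the unsubstituted phenyl group compares.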